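Amine replacement on the shared core: cytotoxicity notes

This account rests on a few compounds, and the source may have more. Where it says the series, first, only, none or still open, it means among the compounds named here.

Measured so far:
compound 1 `CC(C)(C)Nc1nc(=O)c2cc([N+](=O)[O-])cc([N+](=O)[O-])c2s1`: "not determined" (no result reported)
compound 2 `CCNc1nc(=O)c2cc(C(F)(F)F)cc([N+](=O)[O-])c2s1`: > 100000 nM
compound 3 `O=c1nc(N2CCCCC2)sc2c([N+](=O)[O-])cc(C(F)(F)F)cc12`: > 100000 nM

In an ADME assay on Vero cells (Chlorocebus sabaeus) for cytotoxicity, read by MTT assay, with a stated time of 72 h (a higher number here means a weaker inhibitor, a lower number a stronger inhibitor), compound 2 gives > 100000 nM, which is a limit of the assay and not a number. Compound 3 gives > 100000 nM, likewise a limit. Compound 1 gives "not determined" (no result reported), so no value is available for it. Compound 2 therefore stands only at a limit, and of the three entries two sit at the limit of > 100000 nM in this assay, at which 2 of the 3 values shown sit, while the third carries no number.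

Compound 4 `CC1CCN(c2nc(=O)c3cc(C(F)(F)F)cc([N+](=O)[O-])c3s2)CC1` differs from compound 2 by 4-methylpiperidin-1-yl in place of ethylamino on an aromatic carbon. Among the compounds with values here, the one measured step at the same position is a step that the two limits leave unreadable from compound 2 to compound 3; its size cannot be read, both ends sitting at the limit. No direction beyond the scatter can be expected from it, so the expected step that the limit leaves unreadable from compound 2 to compound 4 is in effect none that the assay could show. Compound 4 is estimated at 130000 nM, with a range from 40000 nM to 400000 nM, and the outcome is expected most likely to be a limit again.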

Compound 4, half-maximal inhibitory concentration: > 100000 nM
Compound 4 gave a limit, no number (the forecaster's own chance of this, stated with the estimate: 80%); the middle value does not contradict the limit.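

No new step can be read among compound 2, compound 3 and compound 4, since all three stand at one limit and not at a number: the limit of > 100000 nM in this assay, at which 3 of the 4 values shown sit.

The compounds shown leave open whether any amine on the shared core gives a number rather than a limit in this assay.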